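Urea aryl variation in a diaryl-pyrazole series

A few compounds are considered here, and "the series" means these few. Any claim that something is new, unique, unknown or untested is made for them only; others in the source may bear on it.

Two compounds of the series carry a urea on the shared core. Compound 1 `COc1cc(Cl)cc(-c2nn(-c3cccc(NC(=O)Nc4cc(C(F)(F)F)cc(C(F)(F)F)c4)c3)cc2-c2ccncc2)c1` gives 260 nM in a functional assay on UO-31 cells (Homo sapiens) for inhibition, read by sulforhodamine B assay, with a stated time of 48 h; a lower number here means a stronger inhibitor, a higher number a weaker inhibitor. Compound 2 `COc1cc(Cl)cc(-c2nn(-c3cccc(NC(=O)Nc4ccc(Cl)c(Cl)c4)c3)cc2-c2ccncc2)c1` gives 1890 nM in this assay, the highest of the two numbers, with compound 1 as the nearest at a lower number beyond the scatter. Going by the values given here, no two measured compounds differ in one place only, so no single step has been read. Compound 3 `COc1cc(Cl)cc(-c2nn(-c3cccc(NC(=O)Nc4cccc(C(F)(F)F)c4)c3)cc2-c2ccncc2)c1` is not yet measured; it differs from compound 2 by 3-(trifluoromethyl)phenyl in place of 3,4-dichlorophenyl on an amide-type nitrogen. Since compound 1 with two trifluoromethyl groups reaches 260 nM, a step toward a lower number is expected, a 2.4-fold lower number from compound 2 to compound 3 (0.37 log units; beyond the scatter), beyond the scatter. Compound 3 is estimated at 800 nM, within 300 nM to 2200 nM.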

Compound 3, half-maximal inhibitory concentration: 1030 nM
The estimate for compound 3 lay 1.3-fold (0.11 log units) below the measured number, within the range that was stated.
By their numbers in this assay, from the lowest: compound 1; then compounds 3 and 2 (each within the scatter of the next).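

On the amide-type nitrogen, 3-(trifluoromethyl)phenyl in place of 3,4-dichlorophenyl gives a 1.8-fold lower number from compound 2 to compound 3 (0.26 log units; within the scatter) and so does not separate these two aryl groups. Hydrogen in place of trifluoromethyl on an aromatic carbon gives a 4.0-fold higher number from compound 1 to compound 3 (0.60 log units; beyond the scatter) and is the first single-place change in the series to exceed the scatter, tying the second trifluoromethyl group to the lower number of compound 1. From the compounds shown here alone, whether a nitrile or an amine in place of that second trifluoromethyl group would hold the number of compound 1 remains open. Nothing available explains either step.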